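Ester Group Swap at the Cyclohexane Core: Compound 4

A few compounds are considered here, and "the series" means these few. Any claim that something is new, unique, unknown or untested is made for them only; others in the source may bear on it.

Measured so far in an ADME assay on WI-38 cells (Homo sapiens) for inhibition, read by MTT assay, with a stated time of 72 h; a higher number here means a weaker inhibitor, a lower number a stronger inhibitor:
- compound 1 `O=C(OC1(C(=O)Nc2ccc([N+](=O)[O-])cc2)CCCCC1)c1ccc(Br)cc1` gives 523 nM
- compound 2 `O=C(OC1(C(=O)Nc2ccc([N+](=O)[O-])cc2)CCCCC1)c1ccccc1I` gives 396 nM
- compound 3 `O=C(/C=C/c1ccccc1)OC1(C(=O)Nc2ccc([N+](=O)[O-])cc2)CCCCC1` gives 41 nM

Compound 3 stands at the lowest number of the three. Its gap to the others is well beyond the scatter: a 13-fold lower number from compound 1 to compound 3 (1.11 log units; beyond the scatter) and a 9.7-fold lower number from compound 2 to compound 3 (0.98 log units; beyond the scatter). The step between compound 1 and compound 2, a 1.3-fold lower number from compound 1 to compound 2 (0.12 log units; within the scatter), is within the scatter, so those two cannot be ordered.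

Compound 4 `O=C(OC1(C(=O)Nc2ccc([N+](=O)[O-])cc2)CCCCC1)C(O)c1ccccc1` is the next compound, not yet measured. It differs from compound 3 in one place: hydroxy(phenyl)methyl in place of 2-phenylethenyl on a carbonyl carbon. For the measured compounds named here, no measured step covers exactly this exchange. What the two large steps into compound 3 do show is that the group on this carbonyl carbon moves the number strongly, and that the 2-phenylethenyl group is the one that gave the low number. Leaving it is therefore expected to raise the number again, by a step estimated as a 4.9-fold higher number from compound 3 to compound 4 (0.69 log units; beyond the scatter), most likely landing between compound 3 and the pair of compounds 1 and 2. The estimate for compound 4 in this assay is 200 nM, with a range of 60 nM to 700 nM.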

Compound 4, half-maximal inhibitory concentration: 84.4 nM
Compound 4: the middle estimate sits 2.4-fold (0.37 log units) above what was measured, and the stated range covers the measured number.
By their numbers in this assay, from the lowest: compound 3; then compound 4; then compounds 2 and 1 (each within the scatter of the next).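

In this assay, replacing 2-phenylethenyl with hydroxy(phenyl)methyl gives a 2.1-fold higher number from compound 3 to compound 4 (0.31 log units; beyond the scatter), a modest rise, so a low number at this carbonyl carbon does not depend on 2-phenylethenyl alone, nor on the double bond outside aromatic rings that leaves with it. Compound 4 also stays clearly below the two halogenated aryl esters, with a 4.7-fold lower number from compound 2 to compound 4 (0.67 log units; beyond the scatter) and a 6.2-fold lower number from compound 1 to compound 4 (0.79 log units; beyond the scatter), which means a second group now shares the low end of this short series. No measurement shown explains why these groups differ.

Whether the hydroxy group of hydroxy(phenyl)methyl helps, harms or does nothing remains open, as the compounds shown include no plain benzyl group to compare it with. How an amine on that same carbon would behave is also unknown.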